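Thiazolidinedione aryl ethers: from methylpyridyl to chlorophenyl

The source may hold more compounds than are shown below. What is called first, only, known or untested is meant among the compounds shown, and "the series" means these compounds.

Measured so far:
compound 1 `Cc1ccnc(Oc2ccc(CC3SC(=O)NC3=O)cc2)c1` gives 4280 nM
compound 2 `O=C1NC(=O)C(Cc2ccc(Oc3ccc(Cl)cc3Cl)cc2)S1` gives 101 nM
compound 3 `Cc1cccnc1Oc1ccc(CC2SC(=O)NC2=O)cc1` gives 1090 nM

In a functional assay for agonist activity at Free fatty acid receptor 1 (Homo sapiens), read by FLIPR, in the presence of a further agent that is not named here (a higher number here means that more compound is needed for the effect, a lower number that less compound is needed), compound 3 stands second highest of the three numbers, with compound 1 the nearer neighbour above it and compound 2 well below. Within the data shown here, the one measured step, a 3.9-fold lower number from compound 1 to compound 3 (0.59 log units; beyond the scatter), is a modest one inside the pyridyl pair and does not bear directly on the change now in hand. Compound 4 `O=C1NC(=O)C(Cc2ccc(Oc3ccc(Cl)cc3)cc2)S1` is obtained from compound 3 by 4-chlorophenyl in place of 3-methylpyridin-2-yl on an oxygen on an aromatic ring. Among the measured compounds shown here, no measured step pairs a pyridyl ether with a phenyl ether; the only guide is that compound 2, a chlorine-bearing phenyl ether, gives 101 nM, far below compound 3. Compound 4 is therefore expected to move the same way, by a step of about a 3.1-fold lower number from compound 3 to compound 4 (0.49 log units; beyond the scatter). The estimate for compound 4 is 350 nM, with a range of 100 nM to 1200 nM.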

Compound 4, half-maximal effective concentration: 240 nM
For compound 4 the middle estimate is 1.5-fold (0.16 log units) above the measured one; the range from low to high includes it.
By their numbers in this assay, from the lowest: compound 2; then compound 4; then compound 3; then compound 1.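

In this assay, 4-chlorophenyl on the oxygen gives a lower number than either methylpyridyl group, both with 3-methylpyridin-2-yl (a 4.5-fold lower number from compound 3 to compound 4 (0.66 log units; beyond the scatter)) and with 4-methylpyridin-2-yl (an 18-fold lower number from compound 1 to compound 4 (1.25 log units; beyond the scatter)). The second of these steps is the larger. The phenyl ethers also separate from each other: with hydrogen in place of chloro on an aromatic carbon, the number rises (a 2.4-fold higher number from compound 2 to compound 4 (0.38 log units; beyond the scatter)), so the chlorine pattern on the ring still matters. On these data alone, how a methoxy group or a carboxylic acid in place of chloro would read remains open. No measured evidence accounts for any of these steps.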